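From tert-butyl to pentyl on the shared core

The source may report more compounds than this note shows. Statements on the series, on what has been measured and on what is new or still open speak of the compounds shown alone.

Compound 1 `CC(C)(C)Oc1ccc2nc(N)sc2c1`: > 10 mg/kg
Compound 2 `CC(C)(C)c1ccc2nc(N)sc2c1`: 4 mg/kg

Within the data shown here, in a functional assay on the whole organism with Rattus norvegicus as the target (on this read-out higher numbers stand for an effect only at larger amounts of compound and lower numbers for an effect already at smaller amounts), compound 2 gives 4 mg/kg, the only true number so far. Compound 1 gives > 10 mg/kg, which is a limit. Compound 3 `CCCCCc1ccc2nc(N)sc2c1` carries pentyl in place of tert-butyl on an aromatic carbon. Among the measured compounds shown here, the only measured step, an at least 2.5-fold lower number from compound 1 to compound 2 (0.39 log units; beyond the scatter), changed the group at this same place, so a modest step is expected here, more likely toward a higher number. This means an expected 2.0-fold higher number from compound 2 to compound 3 (0.30 log units; within the scatter). Compound 3 is estimated at 8 mg/kg, with a range from 3 mg/kg to 20 mg/kg.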

Compound 3, dose for half-maximal effect: 7.5 mg/kg
Compound 3: middle estimate off by 1.1-fold (0.03 log units), on the high side; the measured number falls inside the stated range.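

In this assay, replacing tert-butyl with pentyl gives a 1.9-fold higher number from compound 2 to compound 3 (0.27 log units; within the scatter), so these two groups cannot be told apart at this position on an aromatic carbon. Replacing tert-butoxy with pentyl gives an at least 1.3-fold lower number from compound 1 to compound 3 (0.12 log units; that floor lies within the scatter), so this change shows no clear difference between those two groups. Compound 1 gives only a limit, which makes that step a floor: the limit of > 10 mg/kg in this assay, at which 1 of the 3 values shown sits.

The compounds shown leave open whether a longer chain, an amine or a carboxylic acid at this place would stay within the same range on this read-out.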